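The source may hold more compounds than are shown below. What is called first, only, known or untested is meant among the compounds shown, and "the series" means these compounds.

Measured compounds:
- compound 1, `N#Cc1cnc(NCc2cnccc2C(F)(F)F)cc1N[C@H]1C[C@H](O)C1`: 900 nM
- compound 2, `N#Cc1cnc(NCc2cnccc2C(F)(F)F)cc1N[C@H]1CC[C@H](O)CC1`: 350 nM
- compound 3, `CO[C@H]1CC[C@@H](Nc2cc(NCc3cnccc3C(F)(F)F)ncc2C#N)CC1`: 58 nM

All three share one core and differ only in the saturated ring carried on a nitrogen on an aromatic ring. In an assay on isolated protein for inhibition of protein kinase C theta type (Homo sapiens), read by TR-FRET, with a stated time of 2 h (a lower number here means a stronger inhibitor, a higher number a weaker inhibitor), compound 3 gives the lowest number of the three: a 6.0-fold lower number from compound 2 to compound 3 (0.78 log units; beyond the scatter) and a 16-fold lower number from compound 1 to compound 3 (1.19 log units; beyond the scatter), both beyond the usual scatter, so compound 3 is the strongest inhibitor among the measured set.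

Compound 4, `N#Cc1cnc(NCc2cnccc2C(F)(F)F)cc1NC[C@H]1CC[C@@H](O)CC1`, keeps the same atoms as compound 3 but joins them differently: (4-hydroxycyclohexyl)methyl in place of 4-methoxycyclohexyl on a nitrogen on an aromatic ring. For the measured compounds named here, two measured steps bear on this. The exchange of a hydroxyl for a methoxy on the cyclohexyl ring gave a 6.0-fold lower number from compound 2 to compound 3 (0.78 log units; beyond the scatter), so returning to a hydroxyl may give back part of that gain. The move from a smaller ring to a larger one gave a 2.6-fold lower number from compound 1 to compound 2 (0.41 log units; beyond the scatter). Going by the values given here, no measured step shows what attaching the ring through a methyl does, so that part is uncertain.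

Compound 4 is therefore expected to be a weaker inhibitor than compound 3 in this assay, with a step of about a 6.0-fold higher number from compound 3 to compound 4 (0.78 log units; beyond the scatter). The estimate for compound 4 is 350 nM, within a range of 100 nM to 1500 nM.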

Compound 4, half-maximal inhibitory concentration: 58 nM
For compound 4 the middle estimate is 6.0-fold (0.78 log units) above the measured one; the whole stated range lies above it.
By their numbers in this assay, from the lowest: compounds 3 and 4 (each within the scatter of the next); then compound 2; then compound 1.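

At this position, the hydroxyl does not have to be capped as a methoxy to reach the lowest numbers seen in this assay: (4-hydroxycyclohexyl)methyl gives a clear gain over 4-hydroxycyclohexyl (a 6.0-fold lower number from compound 2 to compound 4 (0.78 log units; beyond the scatter)) and a larger one over 3-hydroxycyclobutyl (a 16-fold lower number from compound 1 to compound 4 (1.19 log units; beyond the scatter)). Exchanging 4-methoxycyclohexyl for (4-hydroxycyclohexyl)methyl, which keeps the same atoms but adds a hydrogen-bond donor, leaves the two compounds indistinguishable (no change at the digits printed from compound 3 to compound 4 (within the scatter)), so the shared core tolerates two differently joined groups equally well here. No supporting evidence is available to explain why these two groups give matching numbers.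

The compounds shown leave open whether (4-methoxycyclohexyl)methyl, which would combine the methyl link with the methoxy, would give a lower number than either group alone. They also leave open how a longer chain, such as (4-hydroxycyclohexyl)ethyl, or an amine in place of the hydroxyl on the cyclohexyl ring, would fare in this assay.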